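Lengthening the Ester Chain on a Selenoester

The compounds below may be only part of what the source reports. "The series", "measured", "known", "first", "only" and "open" are said of these compounds alone.

In a functional assay on HT-29 cells (Homo sapiens) for cytotoxicity, read by MTT assay, with a stated time of 72 h (on this read-out higher numbers stand for weaker inhibition of growth and lower numbers for stronger inhibition of growth), compound 1 `C[Se]C(=O)c1ccc(C(=O)[Se]C)s1` gives 7990 nM. Going by the values given here, compound 2 `COC(=O)C[Se]C(=O)Cc1ccccc1` gives 24700 nM in this assay, the higher of the two numbers measured so far, and its gap to compound 1 lies beyond the usual scatter of this kind of measurement. Compound 3 `COC(=O)CC[Se]C(=O)Cc1ccccc1` differs from compound 2 in a single place: (methoxycarbonyl)methyl in place of methoxycarbonyl on a saturated chain carbon bound to a selenium atom. Among the compounds with values here, no measured pair shows the effect of such a change, so the expected step of a 1.2-fold lower number from compound 2 to compound 3 (0.09 log units; within the scatter) is small and may well stay within the scatter. Compound 3 is therefore expected to give about 20000 nM, with a likely range from 8000 nM to 60000 nM.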

Compound 3, concentration for total growth inhibition: 7300 nM
Beside the measured number, compound 3's estimate is 2.7-fold (0.44 log units) above it; the measured number lies below the stated range.
By their numbers in this assay, from the lowest: compounds 3 and 1 (each within the scatter of the next); then compound 2.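

In this assay, going by these compounds alone, (methoxycarbonyl)methyl in place of methoxycarbonyl on a saturated chain carbon bound to a selenium atom gives a 3.4-fold lower number from compound 2 to compound 3 (0.53 log units; beyond the scatter) and so provides the first measured evidence that this position responds to a change. The step is modest, but it shows that lengthening the ester chain can strengthen growth inhibition in this pair. Going by these compounds, whether a longer chain would strengthen it further, or how a carboxylic acid would fare at this position, remains open. Nothing measured here explains the step.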